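From compound 1 to compound 4: one group exchanged

A few compounds are considered here, and "the series" means these few. Any claim that something is new, unique, unknown or untested is made for them only; others in the source may bear on it.

In an ADME assay on microsomes from liver (Homo sapiens) for metabolic stability, with a stated time of 60 min, tested at 1 mg/mL (a lower number here means slower removal, a higher number faster removal of the compound), compound 1 (`COc1nc2ccc(Br)cc2cc1[C@@H](c1cccnc1N(C)C)[C@@](O)(CCN(C)C)c1cccc(F)c1`) gives 45 mL.min-1.g-1, the highest of three numbers. Compound 2 (`COc1nc2ccc(Br)cc2cc1[C@@H](c1ccnc(OC)c1OC)[C@@](O)(CCN(C)C)c1cccc(C)c1`) gives 13 mL.min-1.g-1 and compound 3 (`COc1nc2ccc(Br)cc2cc1[C@@H](c1ccnc(OC)c1OC)[C@@](O)(CCN(C)C)c1cccc(OC(F)F)c1`) gives 11 mL.min-1.g-1. Compound 4 (`CCSc1ccc([C@H](c2cc3cc(Br)ccc3nc2OC)[C@@](O)(CCN(C)C)c2cccc(F)c2)cn1`) keeps the core of compound 1 but carries 6-(ethylsulfanyl)pyridin-3-yl in place of 2-(dimethylamino)pyridin-3-yl on a saturated chain carbon bound to an aromatic carbon and a saturated chain carbon. Within the data shown here, the only measured step (a 1.2-fold lower number from compound 2 to compound 3 (0.07 log units; within the scatter)) lies within the scatter and exchanges difluoromethoxy for methyl, so no measured step covers this exchange. With so little guidance, the estimated step (a 1.1-fold lower number from compound 1 to compound 4 (0.05 log units; within the scatter)) stays within the scatter in this assay, so no real change is expected. Compound 4 is estimated at 40 mL.min-1.g-1 (expected range 15 mL.min-1.g-1 to 100 mL.min-1.g-1).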

Compound 4, intrinsic clearance in microsomes: 11 mL.min-1.g-1
Beside the measured number, compound 4's estimate is 3.6-fold (0.56 log units) above it; the whole stated range lies above it.
By their numbers in this assay, from the lowest: compounds 3, 4 and 2 (each within the scatter of the next); then compound 1.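

Among these compounds, at this saturated chain carbon, this assay responds to the exchange of 2-(dimethylamino)pyridin-3-yl for 6-(ethylsulfanyl)pyridin-3-yl, with a 4.1-fold lower number from compound 1 to compound 4 (0.61 log units; beyond the scatter) as a step that the earlier compounds could not show, as their only step changed a different group. Both groups have the same heavy-atom count, so that count does not separate them. Nothing measured here explains the drop.

From the compounds shown here alone, whether it comes from losing dimethylamino or gaining ethylsulfanyl remains open. So does how a pyridin-3-yl group carrying a morpholine ring or a carboxylic acid would behave in this assay.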